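From piperidin-4-yl to pyrrolidin-3-yl on a carbonyl carbon

The source may report more compounds than this note shows. Statements on the series, on what has been measured and on what is new or still open speak of the compounds shown alone.

In a physicochemical assay for solubility (on this read-out lower numbers stand for lower solubility and higher numbers for higher solubility), compound 1 (`CN(C)c1ccc(C(=O)N2CCC(NS(=O)(=O)c3cc(S(=O)(=O)c4ccccc4)ccc3C(F)(F)F)CC2)cn1`) gives 12500 nM, compound 2 (`O=S(=O)(NC1CCN(S(=O)(=O)c2ccccc2)CC1)c1cc(S(=O)(=O)c2ccccc2)ccc1C(F)(F)F`) gives 25000 nM and compound 3 (`O=C(C1CCNCC1)N1CCC(NS(=O)(=O)c2cc(S(=O)(=O)c3ccccc3)ccc2C(F)(F)F)CC1`) gives 100000 nM. The first two values lie within the scatter of each other. Compound 3 holds the highest number of the three, reached by two modest steps beyond the scatter, an 8.0-fold higher number from compound 1 to compound 3 (0.90 log units; beyond the scatter) and a 4.0-fold higher number from compound 2 to compound 3 (0.60 log units; beyond the scatter).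

Compound 4 (`O=C([C@H]1CCNC1)N1CCC(NS(=O)(=O)c2cc(S(=O)(=O)c3ccccc3)ccc2C(F)(F)F)CC1`) differs in one place: pyrrolidin-3-yl in place of piperidin-4-yl on a carbonyl carbon. In words, pyrrolidin-3-yl stands in place of piperidin-4-yl on a carbonyl carbon, and the entering group has a defined stereocentre. For the measured compounds named here, no measured step exchanges one non-aromatic ring for another, so the data offer no direct precedent. The nearest evidence is an 8.0-fold higher number from compound 1 to compound 3 (0.90 log units; beyond the scatter), made at the same carbonyl carbon, but that exchange is a larger one. No step beyond the scatter is therefore expected in this assay, and the estimate stays close to compound 3 at 100000 nM. The expected change is a 1.1-fold lower number from compound 3 to compound 4 (0.05 log units; within the scatter). Compound 4 is estimated at 90000 nM, with an expected range of 40000 nM to 180000 nM.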

Compound 4, solubility: 25000 nM
Estimate against measurement, compound 4: 3.6-fold (0.56 log units) above, outside the stated range (below it).
By their numbers in this assay, from the lowest: compounds 1, 2 and 4 (each within the scatter of the next); then compound 3.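

At the carbonyl carbon, the change from piperidin-4-yl to pyrrolidin-3-yl is not neutral in this assay: it gives a 4.0-fold lower number from compound 3 to compound 4 (0.60 log units; beyond the scatter), even though the hydrogen-bond donor and acceptor counts stay the same. Compound 4 no longer stands apart from the other two, with no change at the digits printed from compound 2 to compound 4 (within the scatter) and a 2.0-fold higher number from compound 1 to compound 4 (0.30 log units; within the scatter), so among these compounds the high number goes with piperidin-4-yl and does not extend to the other non-aromatic amine ring. Nothing measured here explains the drop.

The step changes ring size and brings in a defined stereocentre together, so the opposite stereoisomer of pyrrolidin-3-yl is needed to separate the two. On these data alone, whether azetidin-3-yl, or piperidin-4-yl carrying a methyl group on its nitrogen, would keep the number of compound 3 also remains open.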